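Tosylate series: triazole aryl halide swap, chloro to fluoro

A few compounds are considered here, and "the series" means these few. Any claim that something is new, unique, unknown or untested is made for them only; others in the source may bear on it.

Measured so far in a functional assay on SMMC-7721 cells (Homo sapiens) for cytotoxicity, read by MTT assay, with a stated time of 4 days; a lower number here means a stronger inhibitor, a higher number a weaker inhibitor:
- compound 1 `C=C1C(=O)[C@]23C[C@@]1(O)CC[C@H]2c1ccc(OS(=O)(=O)c2ccc(C)cc2)c(C)c1[C@@H]3Cn1cc(-c2ccc(Br)cc2)nn1`: 4320 nM
- compound 2 `C=C1C(=O)[C@]23C[C@@]1(O)CC[C@H]2c1ccc(OS(=O)(=O)c2ccc(C)cc2)c(C)c1[C@@H]3Cn1cc(-c2ccc(Cl)cc2)nn1`: 6180 nM
- compound 3 `C=C1C(=O)[C@]23C[C@@]1(O)CC[C@H]2c1ccc(O)c(C)c1[C@@H]3Cn1cc(-c2ccc(Cl)cc2)nn1`: 670 nM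

Compound 2 gives the highest of the three numbers in this assay. Its nearest neighbour is compound 1, a bromo analogue, and the step from one to the other, a 1.4-fold higher number from compound 1 to compound 2 (0.16 log units; within the scatter), stays within the scatter. Among the measured compounds shown here, its furthest neighbour is compound 3, the free phenol, where a 9.2-fold lower number from compound 2 to compound 3 (0.96 log units; beyond the scatter) is the only step beyond the scatter among the three; that step touches the oxygen on the aromatic ring, not the triazole aryl group.

Compound 4 `C=C1C(=O)[C@]23C[C@@]1(O)CC[C@H]2c1ccc(OS(=O)(=O)c2ccc(C)cc2)c(C)c1[C@@H]3Cn1cc(-c2ccc(F)cc2)nn1` differs from compound 2 only in the triazole aryl halide: fluoro in place of chloro on an aromatic carbon. For the measured compounds named here, the one step that bears on it is the halide swap from compound 1 to compound 2, which stayed within the scatter; no other step concerns that position. For compound 4 in this assay, a step of a 1.1-fold higher number from compound 2 to compound 4 (0.05 log units; within the scatter) is therefore expected, that is, no change beyond the scatter. Compound 4 is estimated at 7000 nM, with a range from 3000 nM to 16000 nM.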

Compound 4, half-maximal inhibitory concentration: 4280 nM
The estimate for compound 4 lay 1.6-fold (0.21 log units) above the measured number; measured number inside the range.
By their numbers in this assay, from the lowest: compound 3; then compounds 4, 1 and 2 (each within the scatter of the next).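

In this assay the triazole aryl halide now spans bromo, chloro and fluoro with the tosylate in place, and both new steps stay within the scatter (a 1.4-fold lower number from compound 2 to compound 4 (0.16 log units; within the scatter); a 1.0-fold lower number from compound 1 to compound 4 (0.00 log units; within the scatter)). Compounds 1, 2 and 4 therefore show no readable order among the three halogens at this place, so the swap from 4-chlorophenyl to 4-fluorophenyl does not separate these compounds in this read-out. No measurement shown here accounts for this result.

Whether the same holds with the free phenol stays open, since the only such compound shown, compound 3, carries the 4-chlorophenyl group. Also open, going by these compounds, is how a group other than a halogen, such as an amine or a carboxylic acid, would read at this place on the ring.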